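Swapping the Pyridyl Arm for Benzyl in Compound 1

The compounds below may be only part of what the source reports. "The series", "measured", "known", "first", "only" and "open" are said of these compounds alone.

Compound 1 `FC(F)(F)Oc1ccc(Nc2ncnc3nn(Cc4cccnc4)cc23)cc1` was examined in an ADME assay on BaF3 cells (Mus musculus) for cytotoxicity; a higher number here means that more compound is needed for the effect, a lower number that less compound is needed. In this assay compound 1 gives > 10000 nM, which is a limit of the assay and not a number. Two further compounds carry the same trifluoromethoxy aniline but have different cores. Compound 2 `CC(C)(C)n1ncc2c(Nc3ccc(OC(F)(F)F)cc3)ncnc21` gives 7300 nM in this assay. Compound 3 `NC(=O)c1ccccc1-c1cc(Nc2ccc(OC(F)(F)F)cc2)ncn1` gives > 10000 nM in this assay, again a limit rather than a measured number. Where compound 1 stands is thus set by the limit of > 10000 nM in this assay, at which 2 of the 3 values shown sit, so its result and that of compound 3 cannot be set in order, and only compound 2 returns a number. For the measured compounds named here, no step between two measured compounds that differ in a single place is at hand, so no measured size for any one change exists here.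

The next compound, compound 4 `FC(F)(F)Oc1ccc(Nc2ncnc3nn(Cc4ccccc4)cc23)cc1`, keeps the core of compound 1 and differs in one place: phenyl in place of pyridin-3-yl on a saturated chain carbon bound to an aromatic nitrogen. Compound 1 already sits at the limit of this assay. A step can therefore become visible only if compound 4 comes in as a number. The expected step of a number no higher from compound 1 to compound 4 (the limit leaves the size open) is none beyond the scatter. Compound 4 is estimated at 10000 nM, within 3000 nM to 30000 nM.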

Compound 4, half-maximal effective concentration: > 10000 nM
Compound 4 was reported as a limit; the forecaster's own chance of this, stated with the estimate: 60%; the middle value sits exactly at the limit.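

Compound 4 gives > 10000 nM in this assay, a limit of the assay and not a number. Compound 1 also stands at a limit, so no step from compound 1 to compound 4 can be read, because the two results share one limit: the limit of > 10000 nM in this assay, at which 3 of the 4 values shown sit.

The compounds shown leave open whether phenyl in place of pyridin-3-yl changes the result in this assay at all.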